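Changing the anilide ring of a benzofuran amidoxime

The source may report more compounds than this note shows. Statements on the series, on what has been measured and on what is new or still open speak of the compounds shown alone.

Compound 1 `O/N=C(/Nc1ccccc1)c1ccc2occc2c1` is the parent of this small set. In an assay on isolated protein for inhibition of Indoleamine 2,3-dioxygenase 1 (Homo sapiens), read by spectrophotometry (a lower number here means a stronger inhibitor, a higher number a weaker inhibitor), compound 1 gives only a limit of the assay, > 30000 nM. Compound 2 `O/N=C(/Nc1ccc(Cl)cc1)c1ccc2occc2c1` adds a chloro to the phenyl. Compound 2 likewise gives only a limit in this assay, > 30000 nM. The change a step that the two limits leave unreadable from compound 1 to compound 2 is therefore not readable. Compound 3 `O/N=C(/Nc1cccc(Cl)c1)c1ccc2occc2c1` carries its chloro at a different carbon of the same ring, and compound 3 gives 690 nM in this assay. The step of an at least 43-fold lower number from compound 1 to compound 3 (1.63 log units; beyond the scatter) is the only readable one, and it shows that a single substituent on the phenyl can move the number a long way. The weight of the set sits at the limit of > 30000 nM in this assay, at which 2 of the 3 values shown sit.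

Compound 4 `O/N=C(/NCc1ccco1)c1ccc2occc2c1` replaces the whole phenyl: (furan-2-yl)methyl in place of phenyl on an amine nitrogen. Neither measured step alters this group, so both bear on the new step only loosely; they show that compound 1 is weak and that a small change to its phenyl can give a large gain, but nothing of what a five-membered ring on a methylene does. For compound 4 the expected step of a number no higher from compound 1 to compound 4 (the limit leaves the size open) is therefore set near no change. Compound 4 is estimated at 30000 nM, within a range from 5000 nM to 100000 nM.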

Compound 4, half-maximal inhibitory concentration: > 30000 nM
Compound 4: only a limit was reported (the forecaster's own chance of this, stated with the estimate: 55%); the middle value lies on the limit itself.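

Compound 4 gives only a limit in this assay, > 30000 nM, and compound 1 is also known only by a limit, so no step can be read between these two compounds. The weight of the set now sits at: the limit of > 30000 nM in this assay, at which 3 of the 4 values shown sit. The compounds shown leave open whether any group other than a substituted phenyl on the amine nitrogen gives a readable number.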